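The compounds below may be only part of what the source reports. "The series", "measured", "known", "first", "only" and "open" are said of these compounds alone.

Three measured members of the series share one core and differ only in the ring carried on the amide-type nitrogen of the urea. Compound 3 `COc1cc(-c2nn(-c3cccc(NC(=O)Nc4ccc(Cl)c(C(F)(F)F)c4)c3)cc2-c2ccncc2)ccc1Cl` gives 737 nM in a functional assay on UACC-62 cells (Homo sapiens) for inhibition, read by sulforhodamine B assay, with a stated time of 48 h; a lower number here means a stronger inhibitor of growth, a higher number a weaker inhibitor of growth. Compound 1 `COc1cc(-c2nn(-c3cccc(NC(=O)Nc4ccc(Cl)c(Cl)c4)c3)cc2-c2ccncc2)ccc1Cl` gives 773 nM in this assay, and compound 2 `COc1cc(-c2nn(-c3cccc(NC(=O)Nc4cccc(C(F)(F)F)c4)c3)cc2-c2ccncc2)ccc1Cl` gives 725 nM. Compound 3 stands second highest of the three numbers; the steps leading to it are a 1.0-fold lower number from compound 1 to compound 3 (0.02 log units; within the scatter) and a 1.0-fold higher number from compound 2 to compound 3 (0.01 log units; within the scatter), and the third step, a 1.1-fold lower number from compound 1 to compound 2 (0.03 log units; within the scatter), is likewise within the scatter, so the three values cannot be told apart.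

Compound 4 `COc1cc(-c2nn(-c3cccc(NC(=O)c4ccccc4)c3)cc2-c2ccncc2)ccc1Cl` is built from compound 3 by phenyl in place of (4-chloro-3-(trifluoromethyl)phenyl)amino on a carbonyl carbon. Within the data shown here, none of the measured steps covers this change: each swapped one substituted ring for another while keeping the urea, whereas here the (4-chloro-3-(trifluoromethyl)phenyl)amino group is removed as a whole and a bare phenyl takes its place on the carbonyl carbon. Among the measured compounds shown here, the measured steps show only that the ring on the amide-type nitrogen may be varied without effect; they give no guide to removing it. The expectation for compound 4 in this assay is therefore loosely held and leans to a higher number, with a 3.4-fold higher number from compound 3 to compound 4 (0.53 log units; beyond the scatter) as the expected step. Compound 4 is estimated at 2500 nM, within 600 nM to 10000 nM.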

Compound 4, concentration for 50% growth inhibition: 692 nM
For compound 4 the middle estimate is 3.6-fold (0.56 log units) above the measured one, within the range that was stated.
By their numbers in this assay, from the lowest: compounds 4, 2, 3 and 1 (each within the scatter of the next).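

In this assay, the change to phenyl on the carbonyl carbon gives a 1.1-fold lower number from compound 3 to compound 4 (0.03 log units; within the scatter), and the matching changes give a 1.0-fold lower number from compound 2 to compound 4 (0.02 log units; within the scatter) and a 1.1-fold lower number from compound 1 to compound 4 (0.05 log units; within the scatter). Among these compounds, the earlier compounds showed only that one substituted ring could replace another while the urea stayed; here the whole arylamino group, including its nitrogen and hydrogen-bond donor, gives way to phenyl with no change that can be told from the scatter. No measurement on hand bears on why the number holds across this change.

From the compounds shown here alone, whether this position needs an aromatic ring at all remains open, and a methyl or a longer alkyl chain on the carbonyl carbon would address that. Also open, going by these compounds, is how the number responds to an amine or a carboxylic acid on the phenyl ring.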